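The compounds below may be only part of what the source reports. "The series", "measured", "known", "first", "only" and "open" are said of these compounds alone.

For the measured compounds named here, compound 1, with the structure `COc1cc2c(cc1O)CCC(C)(CC(=O)O)O2`, stands at the top of the two numbers so far in an ADME assay on SH-SY5Y cells (Homo sapiens) for cytotoxicity, read by MTT assay, with a stated time of 24 h, tested at 6.3 uM (a higher number here means a weaker effect of the compound at the concentration tested, a lower number a stronger effect), where compound 1 gives 100%. Its nearest neighbour is compound 2, `COc1cc2c(cc1O)CCC(C)(CC(=O)N[C@@H](C)C(=O)O)O2`, which in this assay gives 94.6%; the step of a number 5.4 percentage points lower from compound 1 to compound 2 (within the scatter) stays within the scatter, so the two compounds cannot be ordered against each other. Compound 3, `COc1cc2c(cc1O)CCC(C)(CC(N)C(=O)O)O2`, has not yet been measured in this assay. It differs from compound 1 in that (amino(carboxy)methyl in place of carboxy on a saturated chain carbon bound to a saturated ring carbon). Going by the values given here, only one measured step exists to judge this change by, and it is the one from compound 1 to compound 2, which reworks the same chain end on its carbonyl carbon and moves the number by an amount within the scatter. On that basis no step beyond the scatter is expected for compound 3 in this assay, and the expected step of a number 3 percentage points lower from compound 1 to compound 3 (within the scatter) is estimated to be small. Compound 3 is therefore expected to give about 97% in this assay, with a range from 84% to 106%.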

Compound 3, a percentage reported as activity, at one concentration (the size of the read-out at that concentration, not a potency): 100%
Estimate against measurement, compound 3: 3 percentage points below; measured number inside the range.
By their numbers in this assay, from the lowest: compounds 2, 1 and 3 (each within the scatter of the next).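

In this assay the exchange of carboxy for amino(carboxy)methyl on a saturated chain carbon bound to a saturated ring carbon gives no change at the digits printed from compound 1 to compound 3 (within the scatter) and so leaves the read-out where it was. The earlier pair tested only a rework on the carbonyl carbon, with (1-carboxyethyl)amino in place of hydroxy and a number 5.4 percentage points lower from compound 1 to compound 2 (within the scatter) as its result, whereas this change adds an amino group to the chain and keeps the carboxy group, so a second kind of change at this chain end also stays within the scatter. Nothing available bears on why this chain end tolerates both changes at this one concentration.

The three compounds leave open whether an ester or a primary amide in place of the carboxylic acid, or a longer chain carrying the same amine and acid, would move the number beyond the scatter. They also leave open whether an amine alone at this chain end, without any carboxylic acid, would behave as compound 3 does.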